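The compounds below may be only part of what the source reports. "The series", "measured", "known", "first", "only" and "open" are said of these compounds alone.

Compound 1, `Cc1ccccc1CNC(=O)c1nc(-c2ccc(F)cc2)n(CC[C@@H](O)C[C@@H](O)CC(=O)O)c1C1CC1`, gives 0.44 in a physicochemical assay for lipophilicity, using the shake flask method, at pH 7.4; on this read-out higher numbers stand for higher lipophilicity and lower numbers for lower lipophilicity.
Compound 2, `O=C(O)C[C@H](O)C[C@H](O)CCn1c(-c2ccc(F)cc2)nc(C(=O)NCc2cccc(F)c2)c1C1CC1`, gives 0.51 in this assay.
Compound 3, `O=C(O)C[C@H](O)C[C@H](O)CCn1c(-c2ccc(F)cc2)nc(C(=O)NCc2ccc(F)cc2)c1C1CC1`, gives 0.17 in this assay.

Among these three, compound 2 shows the highest number, though the gap to compound 1 is within the scatter a number 0.07 log units higher from compound 1 to compound 2 (within the scatter), while the gap to compound 3 is beyond it a number 0.34 log units lower from compound 2 to compound 3 (beyond the scatter). Compound 4, `CN(C)S(=O)(=O)c1ccc(CNC(=O)c2nc(-c3ccc(F)cc3)n(CC[C@@H](O)C[C@@H](O)CC(=O)O)c2C2CC2)cc1`, has not yet been measured. It differs from compound 2 in one place: 4-(dimethylsulfamoyl)phenyl in place of 3-fluorophenyl on a saturated chain carbon bound to an amide-type nitrogen. The measured steps all concern swaps at this same position, but each exchanged only a fluorine or a methyl on the ring, and all were small: a number 0.07 log units higher from compound 1 to compound 2 (within the scatter), a number 0.27 log units lower from compound 1 to compound 3 (within the scatter), a number 0.34 log units lower from compound 2 to compound 3 (beyond the scatter). None of them introduces hydrogen-bond acceptors, so they give little guidance here. Since the entering group adds two hydrogen-bond acceptors and five more heavy atoms than the group that leaves, a clearly lower number than that of compound 2 is expected, a number 1.01 log units lower from compound 2 to compound 4 (beyond the scatter). For compound 4 the estimated value in this assay is -0.5, with a range from -1.1 to 0.1.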

Compound 4, distribution coefficient: -0.46
Compound 4: middle estimate off by 0.04 log units, on the low side, within the range that was stated.
By their numbers in this assay, from the lowest: compound 4; then compounds 3, 1 and 2 (each within the scatter of the next, the first and the last beyond it).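

Replacing the ring substituents with a dimethylsulfamoyl group moves the number in this assay much further than the earlier swaps of a fluorine or a methyl did (a number 0.97 log units lower from compound 2 to compound 4 (beyond the scatter); a number 0.90 log units lower from compound 1 to compound 4 (beyond the scatter)). Even against compound 3, the compound with the lowest number among the earlier three, the exchange of fluoro for dimethylsulfamoyl on an aromatic carbon still gives a step beyond the scatter (a number 0.63 log units lower from compound 3 to compound 4 (beyond the scatter)), so this position can shift the read-out well beyond the narrow band the earlier compounds occupied. Nothing available here accounts for the size of this fall.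

On these data alone, it remains open whether a methyl sulfone, an unsubstituted sulfonamide or a carboxylic acid in place of dimethylsulfamoyl would lower the number as far. Also open, as far as these compounds go, is whether dimethylsulfamoyl would give a step of similar size on a different core.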